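The source may hold more compounds than are shown below. What is called first, only, known or untested is meant among the compounds shown, and "the series" means these compounds.

Working notes on the series. Compound 2 `CCCS(=O)(=O)Nc1ccc(F)c(C(=O)c2n[nH]c3ncc(-c4ccc(OC)cc4)cc23)c1F` gives 4.2% in an assay for binding affinity to dual specificity mitogen-activated protein kinase kinase 4 (Homo sapiens), read by KINOMEscan, tested at 100 nM (on this read-out higher numbers stand for a weaker effect at the one concentration tested and lower numbers for a stronger effect), the lowest of the two numbers recorded so far; its nearest neighbour is compound 1 `CCCS(=O)(=O)Nc1ccc(F)c(C(=O)c2n[nH]c3ncc(-c4ccc(C)cc4)cc23)c1F`, which in this assay gives 5.4%, and the step of a number 1.2 percentage points lower from compound 1 to compound 2 (within the scatter) is within the scatter, so the two compounds are not distinguished on this read-out.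

Compound 3 `CCCS(=O)(=O)Nc1ccc(F)c(C(=O)c2n[nH]c3ncc(-c4ccccc4O)cc23)c1F` is still to be measured. It differs from compound 2 by 2-hydroxyphenyl in place of 4-methoxyphenyl on an aromatic carbon.

Among the measured compounds shown here, the only measured step, from compound 1 to compound 2, concerns a different substituent on the same ring and was within the scatter (a number 1.2 percentage points lower from compound 1 to compound 2 (within the scatter)). For the measured compounds named here, no measured pair covers the replacement of 4-methoxyphenyl by 2-hydroxyphenyl, so the expectation rests on the observation that both compounds measured so far sit at low numbers in this assay, with no evidence yet of sensitivity to changes on this ring. The expected step of a number 3.8 percentage points higher from compound 2 to compound 3 (within the scatter) is therefore taken as none beyond the scatter, with a wide range to allow for an uncovered change. Compound 3 is estimated at 8% in this assay, with a range from 2% to 30%.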

Compound 3, a percentage reported as activity, at one concentration (the size of the read-out at that concentration, not a potency): 9%
For compound 3 the middle estimate is 1 percentage points below the measured one; the measured number falls inside the stated range.
By their numbers in this assay, from the lowest: compounds 2, 1 and 3 (each within the scatter of the next).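

In this assay, putting 2-hydroxyphenyl in place of 4-methoxyphenyl gives a number 4.8 percentage points higher from compound 2 to compound 3 (within the scatter) and putting it in place of 4-methylphenyl gives a number 3.6 percentage points higher from compound 1 to compound 3 (within the scatter) on the same aromatic carbon. The earlier step covered only methoxy in place of methyl on the aryl group, whereas these steps change where the substituent sits on that ring and bring in a hydrogen-bond donor, and still none of them goes beyond the scatter, so all three aryl groups remain undistinguished on this read-out at the one concentration tested. No supporting data bear on why these changes leave the read-out unseparated.

With the substituent and its place on the ring changing together, the two contributions cannot be told apart, and 2-methoxyphenyl or 4-hydroxyphenyl at this carbon would be needed to separate them. Also open is whether a basic amine, a carboxylic acid or a longer alkyl chain on this ring would move the number beyond the scatter, and a read-out at one concentration gives no potency for any of these compounds.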